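The source may hold more compounds than are shown below. What is called first, only, known or untested is meant among the compounds shown, and "the series" means these compounds.

This account follows a small set of compounds tested in a functional assay on SEM cells (Homo sapiens) for antiproliferative activity, with a stated time of 72 h; a lower number here means that less compound is needed, a higher number that more compound is needed for the effect. Two of them, compound 1 `COc1ccc(-c2cc(=O)c3c(OC)cc(OC)cc3n2S(=O)(=O)c2cc(F)c(F)c(F)c2)cc1` and compound 2 `COc1ccc(-c2cc(=O)c3c(OC)cc(OC)cc3n2S(=O)(=O)c2ccc(Br)cc2)cc1`, share a sulfonylated core and carry no result there: compound 1 has "not determined" (no result reported), and compound 2 likewise has "not determined" (no result reported). The third, compound 3 `COC(=O)c1cc(=O)c2cc(NC(=O)Nc3ccc(Cl)c(C(F)(F)F)c3)ccc2[nH]1`, belongs to a different series with a urea on its core, and in this assay compound 3 reaches only a limit of the assay, > 6350 nM. Where compound 3 stands is therefore known only as the limit of > 6350 nM in this assay, at which 1 of the 3 values shown sits, and no step between measured compounds can be drawn from these three entries.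

The compound not yet measured, compound 4 `COC(=O)c1cc(=O)c2cc(NC(=O)Nc3ccc(Cl)c(Cl)c3)ccc2[nH]1`, is derived from compound 3 by a single change: chloro in place of trifluoromethyl on an aromatic carbon. Within the data shown here, no measured pair shows what such a change does in this assay, so the expectation rests on compound 3 alone and on the closeness of the two structures. The step from compound 3 to compound 4 is expected to be a step that the limit leaves unreadable from compound 3 to compound 4, no larger than the usual scatter. Compound 4 is accordingly estimated at 9000 nM in this assay, with a range from 3000 nM to 30000 nM, and it is considered likely that the assay again reports only a limit for compound 4.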

Compound 4, half-maximal effective concentration: > 6350 nM
Compound 4 gave a limit, no number; the forecaster's own chance of this, stated with the estimate: 70%; the middle value is on the limit's open side.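

Compound 3 and compound 4 both end at a limit of the assay, not at a number, and no step between them can be read: the limit of > 6350 nM in this assay, at which 2 of the 4 values shown sit.

What the compounds shown leave open is what chloro in place of trifluoromethyl on an aromatic carbon does in this assay, and where either compound lies past that limit.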